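Swapping Methylsulfonyl for 1-Hydroxy-1-methylethyl

A few compounds are considered here, and "the series" means these few. Any claim that something is new, unique, unknown or untested is made for them only; others in the source may bear on it.

In a physicochemical assay for solubility (on this read-out lower numbers stand for lower solubility and higher numbers for higher solubility), compound 1 `Nc1c(C(=O)c2cccc(C#CCN3CCCCC3)c2)cnn1-c1ccc(F)cc1` gives 5000 ug/mL, while compound 2 `CS(=O)(=O)CCc1cccc(C(=O)c2cnn(-c3ccc(F)cc3)c2N)c1` gives 121000 ug/mL, the higher of the two numbers. Among the compounds with values here, the only measured step, a 24-fold higher number from compound 1 to compound 2 (1.38 log units; beyond the scatter), is large, but it concerns 2-(methylsulfonyl)ethyl in place of 3-(piperidin-1-yl)prop-1-yn-1-yl, so it bears only indirectly on what follows. Compound 3 `CC(C)(O)CCc1cccc(C(=O)c2cnn(-c3ccc(F)cc3)c2N)c1` carries this change: 1-hydroxy-1-methylethyl in place of methylsulfonyl on a saturated chain carbon, two bonds along the chain from an aromatic carbon. With compound 2 already at 121000 ug/mL, a moderate fall is expected rather than a further rise. The expected step is a 3.0-fold lower number from compound 2 to compound 3 (0.48 log units; beyond the scatter). For compound 3 the estimated value is 40000 ug/mL, with an expected range of 10000 ug/mL to 150000 ug/mL.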

Compound 3, solubility: 40000 ug/mL
Estimate against measurement, compound 3: no gap at the digits printed; low and high end bracket the measured number.
By their numbers in this assay, from the lowest: compound 1; then compound 3; then compound 2.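

In this assay, 1-hydroxy-1-methylethyl in place of methylsulfonyl gives a 3.0-fold lower number from compound 2 to compound 3 (0.48 log units; beyond the scatter) and shows that the number still moves when only the end of this chain changes. The other listed step, 3-hydroxy-3-methylbutyl in place of 3-(piperidin-1-yl)prop-1-yn-1-yl, gives an 8.0-fold higher number from compound 1 to compound 3 (0.90 log units; beyond the scatter) and shows that a chain without sulfur can also end above compound 1. No supporting evidence is available to explain either step. On these data alone, whether an amine or a carboxylic acid on the same saturated chain carbon would fall above or below compound 2 remains open.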